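A few compounds are considered here, and "the series" means these few. Any claim that something is new, unique, unknown or untested is made for them only; others in the source may bear on it.

Working notes on the series. In an assay on LM cells for displacement of a labelled ligand from Neuropeptide Y receptor type 5 (Homo sapiens) (on this read-out lower numbers stand for stronger inhibition and higher numbers for weaker inhibition), compound 1 `O=Cc1cccc(C2=NC(c3ccc(F)cc3)(c3ccc(F)cc3)CN2)c1` gives 8.7 nM, and compound 2 `OCc1cccc(C2=NC(c3ccc(F)cc3)(c3ccc(F)cc3)CN2)c1` gives 59 nM. Within the data shown here, the only step between measured compounds, a 6.8-fold higher number from compound 1 to compound 2 (0.83 log units; beyond the scatter), is a hydroxymethyl in place of formyl on an aromatic carbon. On the two numbers shown, compound 2 stands highest; its nearest neighbour is compound 1, from which it is separated by that modest step beyond the scatter.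

Compound 3 `Fc1ccc(C2(c3ccc(F)cc3)CNC(c3cccs3)=N2)cc1` is not yet measured. Its change from compound 2 is thiophen-2-yl in place of 3-(hydroxymethyl)phenyl on a carbon with a double bond to nitrogen. Among the measured compounds shown here, no measured step bears directly on this exchange: the step from compound 1 to compound 2 only alters the group carried on the phenyl ring, whereas here the whole 3-(hydroxymethyl)phenyl ring leaves and a five-membered ring with one hetero atom enters, removing the one hydrogen-bond donor. The two numbers shown therefore give only a weak guide. It is expected that the step of a 1.5-fold lower number from compound 2 to compound 3 (0.17 log units; within the scatter) stays small, with compound 3 estimated at 40 nM, in a range of 10 nM to 200 nM.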

Compound 3, half-maximal inhibitory concentration: 54 nM
Estimate against measurement, compound 3: 1.4-fold (0.13 log units) below, within the range that was stated.
By their numbers in this assay, from the lowest: compound 1; then compounds 3 and 2 (each within the scatter of the next).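

In this assay, the whole aromatic group on the carbon with a double bond to nitrogen can be exchanged with little consequence for the number: a 1.1-fold lower number from compound 2 to compound 3 (0.04 log units; within the scatter) leaves 3-(hydroxymethyl)phenyl and thiophen-2-yl inseparable, so the hydrogen-bond donor of the hydroxymethyl group is not needed to reach this level. Thiophen-2-yl in place of 3-formylphenyl gives a 6.2-fold higher number from compound 1 to compound 3 (0.79 log units; beyond the scatter), which leaves the 3-formylphenyl group alone at the low end among the three groups shown. Nothing measured here explains these numbers.

As far as these compounds go, it remains open whether the formyl group would keep the number low on a thiophen-2-yl ring rather than on phenyl. From the compounds shown here alone, how an aminomethyl group or a carboxylic acid on the phenyl ring would read in this assay also remains open.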